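A few compounds are considered here, and "the series" means these few. Any claim that something is new, unique, unknown or untested is made for them only; others in the source may bear on it.

Series values in a physicochemical assay for solubility, read by nephelometry, in phosphate buffer, measured as kinetic solubility, with a stated time of 30 min, at pH 6.5; on this read-out lower numbers stand for lower solubility and higher numbers for higher solubility:
- compound 1 `O=C(O)CNC(=O)COc1ccc([C@H]2CC[C@]3(CC2)OOC2(O3)C3CC4CC(C3)CC2C4)cc1`: 12.5 ug/mL
- compound 2 `O=C(O)COc1ccc([C@H]2CC[C@]3(CC2)OOC2(O3)C3CC4CC(C3)CC2C4)cc1`: < 1.6 ug/mL (a limit)
- compound 3 `CS(=O)(=O)NC(=O)COc1ccc([C@H]2CC[C@]3(CC2)OOC2(O3)C3CC4CC(C3)CC2C4)cc1`: < 1.6 ug/mL (a limit)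

Compound 3 gives only a limit and no number. That limit is the limit of < 1.6 ug/mL in this assay, at which 2 of the 3 values shown sit. For the measured compounds named here, compound 1 is the only compound with a number.

Compound 4 `O=C(O)c1ccc([C@H]2CC[C@]3(CC2)OOC2(O3)C3CC4CC(C3)CC2C4)cc1` carries carboxy in place of ((methylsulfonyl)carbamoyl)methoxy on an aromatic carbon, para to a large group: carboxy in place of ((methylsulfonyl)carbamoyl)methoxy on an aromatic carbon.

Going by the values given here, no measured step makes this exchange, so the evidence is indirect. Two steps beyond the scatter lead down to the limit: an at least 7.8-fold lower number from compound 1 to compound 2 (0.89 log units; beyond the scatter) and an at least 7.8-fold lower number from compound 1 to compound 3 (0.89 log units; beyond the scatter). Both remove the (carboxymethyl)amino arrangement of compound 1, and compound 4 lacks it as well. The step that the two limits leave unreadable from compound 2 to compound 3 gives no size to work from. Compound 2 is the closest comparison, as it also ends in hydroxy on a carbonyl carbon, and an at least 7.8-fold lower number from compound 1 to compound 2 (0.89 log units; beyond the scatter) took it to the limit. Compound 4 is therefore expected to stay close to compound 3, and a report of only a limit is more likely than not. In this assay the expected step is an at least 1.2-fold higher number from compound 3 to compound 4 (0.09 log units; that floor lies within the scatter), with none expected beyond the scatter. For compound 4 the estimated value is 2 ug/mL, with an expected range of 1 ug/mL to 6 ug/mL.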

Compound 4, solubility: < 3.1 ug/mL
Compound 4: a limit, no number (the forecaster's own chance of this, stated with the estimate: 60%); the middle value is on the limit's open side.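

In this assay compound 4 gives < 3.1 ug/mL, which is a limit and not a number: the limit of < 3.1 ug/mL in this assay, at which 1 of the 4 values shown sits.

A carboxy set directly on the aromatic carbon, para to a large group, therefore joins the carboxymethoxy of compound 2 and the ((methylsulfonyl)carbamoyl)methoxy of compound 3 in giving no number, so this end of the series now spans three different groups at this position without a readable value. Against the only compound with a number, the result is an at least 4.0-fold lower number from compound 1 to compound 4 (0.60 log units; beyond the scatter), which extends the drop seen on leaving the ((carboxymethyl)carbamoyl)methoxy group to a change that also removes the chain altogether.

The steps among compound 2, compound 3 and compound 4 cannot be read, so no order among these three can be stated, and whether the shorter group differs at all from the two longer ones stays open. Also open, as far as these compounds go, is whether the number at compound 1 depends on its terminal carboxylic acid or on the amide alone; a simple amine or a longer chain on that carbonyl carbon would separate the two.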